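Triazole benzyl series: methylsulfanyl in place of trifluoromethyl

This account rests on a few compounds, and the source may have more. Where it says the series, first, only, none or still open, it means among the compounds named here.

Compound 1 `Clc1cccc(-n2ncnc2Cc2ccccc2)c1Cl`: 209 nM
Compound 2 `Clc1cccc(-c2ccnn2Cc2ccccc2)c1Cl`: 6030 nM
Compound 3 `FC(F)(F)c1ccccc1Cn1cnnc1-c1cccc(Cl)c1Cl`: 132 nM

In a functional assay for antagonist activity at P2X purinoceptor 7 (Homo sapiens) (on this read-out lower numbers stand for stronger inhibition and higher numbers for weaker inhibition), compound 3 has the lowest of the three numbers. Its nearest neighbour is compound 1, whose number lies within the scatter of that of compound 3, so no order between the two can be claimed; compound 2 stands far beyond the scatter of compound 3.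

Compound 4 `CSc1ccccc1Cn1cnnc1-c1cccc(Cl)c1Cl` differs from compound 3 in one place: methylsulfanyl in place of trifluoromethyl on an aromatic carbon. As compound 1 and compound 3 show, the group at this place has so far left the result within the scatter, so no step beyond the scatter is expected from compound 3 to compound 4 in this assay. The expected step is a 1.5-fold higher number from compound 3 to compound 4 (0.18 log units; within the scatter). Compound 4 is therefore estimated at 200 nM, with a range from 60 nM to 700 nM.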

Compound 4, half-maximal inhibitory concentration: 49 nM
Estimate against measurement, compound 4: 4.1-fold (0.61 log units) above, and the stated range ends above it.
By their numbers in this assay, from the lowest: compound 4; then compounds 3 and 1 (each within the scatter of the next); then compound 2.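

In this assay, methylsulfanyl in place of trifluoromethyl gives a 2.7-fold lower number from compound 3 to compound 4 (0.43 log units; beyond the scatter), a modest step but one beyond the scatter. This shows that the group on this aromatic carbon, ortho to a large group, can change the result, and that trifluoromethyl is not required there for inhibition. Nothing measured here explains the step. The compounds shown leave open whether the sulfur itself matters, which a methoxy group at this place could test. They also leave open whether a longer chain, such as ethylsulfanyl, would keep the lower number.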